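From 3-Bromophenyl to 3,4-Dichlorophenyl on the Carbonyl

The source may report more compounds than this note shows. Statements on the series, on what has been measured and on what is new or still open speak of the compounds shown alone.

In a functional assay on MCF7 cells (Homo sapiens) for antiproliferative activity, read by MTT assay, with a stated time of 72 h (on this read-out lower numbers stand for stronger inhibition and higher numbers for weaker inhibition), compound 1 `CNc1cc(C)c2cc(NC(=O)c3ccc(Cl)c(Cl)c3)ccc2n1` gives 2520 nM and compound 3 `CCN1CCN(c2cc(C)c3cc(NC(=O)c4cccc(Br)c4)ccc3n2)CC1` gives 11600 nM as the higher of these two numbers. Compound 2 `CCN(CC)c1cc(C)c2cc(NC(=O)c3ccc(Cl)c(Cl)c3)ccc2n1` reports only a limit of > 50000 nM rather than a number. Compound 4 `CCN1CCN(c2cc(C)c3cc(NC(=O)c4ccc(Cl)c(Cl)c4)ccc3n2)CC1` differs from compound 3 by 3,4-dichlorophenyl in place of 3-bromophenyl on a carbonyl carbon in one swap: 3,4-dichlorophenyl in place of 3-bromophenyl on a carbonyl carbon. Among the compounds with values here, the one measured step of an at least 19-fold higher number from compound 1 to compound 2 (1.29 log units; beyond the scatter) is large and beyond the scatter, but it puts diethylamino in place of methylamino on an aromatic carbon, so it does not speak to this swap. Within the data shown here, no measured pair changes the group on the carbonyl carbon, so no step beyond the scatter is expected in this assay here. The expected step is a 1.3-fold lower number from compound 3 to compound 4 (0.11 log units; within the scatter) and remains only an estimate. For compound 4 the estimated value is 9000 nM with an expected range from 3000 nM to 30000 nM in this measurement.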

Compound 4, half-maximal inhibitory concentration: 1380 nM
Estimate against measurement, compound 4: 6.5-fold (0.81 log units) above, and the stated range ends above it.
By their numbers in this assay, from the lowest: compounds 4 and 1 (each within the scatter of the next); then compound 3. At a limit, above all of these: compound 2.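

Within the data shown here, the group on the carbonyl carbon matters here, which no earlier pair could show: with 4-ethylpiperazin-1-yl held fixed, 3,4-dichlorophenyl in place of 3-bromophenyl gives an 8.4-fold lower number from compound 3 to compound 4 (0.92 log units; beyond the scatter). With 3,4-dichlorophenyl held fixed, the group on the aromatic carbon gives two different results: a 1.8-fold lower number from compound 1 to compound 4 (0.26 log units; within the scatter), but an at least 36-fold lower number from compound 2 to compound 4 (1.55 log units; beyond the scatter). The figure for compound 2 is a limit, not a number: the limit of > 50000 nM in this assay, at which 1 of the 4 values shown sits.

Still open, going by these compounds, is how a 3-chlorophenyl or a plain phenyl on the carbonyl carbon would read. Also open, on these data alone, is whether a morpholine on the aromatic carbon would behave like 4-ethylpiperazin-1-yl.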